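The source may hold more compounds than are shown below. What is called first, only, known or untested is meant among the compounds shown, and "the series" means these compounds.

Of the compounds shown here, two from this series have been measured, and they share the same core with a urea-hydrazone arm. Compound 1 `COc1cc2c(Oc3ccc(NC(=O)N/N=C/c4ccc(C(F)(F)F)cc4)cc3F)ccnc2cc1OCCCN1CCCC1` carries a trifluoromethyl on its terminal phenyl ring and a pyrrolidine on its side chain. Compound 2 `COc1ccc(/C=N/NC(=O)Nc2ccc(Oc3ccnc4cc(OCCCN5CCCCC5)c(OC)cc34)c(F)c2)cc1` carries a methoxy on that phenyl ring and a piperidine on the side chain. In a functional assay on A549 cells (Homo sapiens) for cytotoxicity, read by MTT assay, with a stated time of 72 h (a higher number here means a weaker inhibitor, a lower number a stronger inhibitor), compound 2 gives 540 nM, and compound 1 gives 790 nM. These two numbers lie within the usual scatter of each other, so nothing can be read from their order: both compounds behave much the same.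

Compound 3 `COc1cc2c(Oc3ccc(NC(=O)N/N=C/c4ccc(C(F)(F)F)cc4)cc3F)ccnc2cc1OCCCN1CCCCC1` has not been measured yet. It keeps the piperidine side chain of compound 2, and the difference is trifluoromethyl in place of methoxy on an aromatic carbon. Among the measured compounds shown here, no pair of measured compounds shows this exact change on its own, so its size has to be judged indirectly. Compound 1 already carries the trifluoromethyl and its value is close to that of compound 2, which suggests the change does little. The expected step of a 1.3-fold higher number from compound 2 to compound 3 (0.11 log units; within the scatter) is therefore small, with no clear direction beyond the scatter. Compound 3 is expected to give about 700 nM, within a range from 300 nM to 1600 nM.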

Compound 3, half-maximal inhibitory concentration: 660 nM
Compound 3: middle estimate off by 1.1-fold (0.03 log units), on the high side; low and high end bracket the measured number.
By their numbers in this assay, from the lowest: compounds 2, 3 and 1 (each within the scatter of the next).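

In this assay, the change from 4-methoxyphenyl to 4-(trifluoromethyl)phenyl can now be read on its own, with the piperidine side chain held fixed: it gives a 1.2-fold higher number from compound 2 to compound 3 (0.09 log units; within the scatter) and so shows no clear effect at this position, para to a large group. Among the compounds shown here, the side chain can also be read alone for the first time, with the trifluoromethyl held fixed: piperidin-1-yl in place of pyrrolidin-1-yl gives a 1.2-fold lower number from compound 1 to compound 3 (0.08 log units; within the scatter) and so also shows no clear effect, which means that neither of the two differences between compound 1 and compound 2 stands out from the scatter in this set. Nothing given here speaks to the reason these values lie so close together.

Only two groups on the terminal ring and two rings on the side chain are shown, so it remains open whether a carboxylic acid or an amine on that ring, or a morpholine at the end of the chain, would give a step beyond the scatter. On these data alone, a longer chain between the oxygen and the ring at its end also remains open, as does whether these close values hold in other cell lines.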